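Methylsulfonyl for trifluoromethyl on the amide aryl ring

The compounds below may be only part of what the source reports. "The series", "measured", "known", "first", "only" and "open" are said of these compounds alone.

Compound 1 `O=C(Nc1ccc(Cl)c(-c2nnc3c(Cl)cccn23)c1)c1ccc(C(F)(F)F)cc1Cl` is the reference point of these notes. In a functional assay on AN3-CA cells (Homo sapiens) for antiproliferative activity, read by MTT assay, with a stated time of 72 h (a higher number here means a weaker inhibitor, a lower number a stronger inhibitor), compound 1 gives > 100000 nM, which is a limit of the assay and not a number. Compound 2 `O=C(Nc1ccc(Cl)c(-c2nnc3c(Cl)cccn23)c1)c1ccc(Cl)cc1` also returns a limit: in this assay compound 2 gives > 100000 nM. For the measured compounds named here, compound 3 `O=C(Nc1ccc(Cl)c(-c2nnc3c(Cl)cccn23)c1)c1ccc(C(F)(F)F)cc1F` is the only member with a measured number, giving 41200 nM in this assay. Going by the values given here, the one measured step, fluoro in place of chloro on an aromatic carbon, is an at least 2.4-fold lower number from compound 1 to compound 3 (0.38 log units; beyond the scatter); since it starts from the limit of > 100000 nM in this assay, at which 2 of the 3 values shown sit, only its lower bound is known.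

Compound 4 `CS(=O)(=O)c1ccc(C(=O)Nc2ccc(Cl)c(-c3nnc4c(Cl)cccn34)c2)c(Cl)c1` is obtained from compound 1 by methylsulfonyl in place of trifluoromethyl on an aromatic carbon. Among the compounds with values here, none of the measured steps touches this position or this pair of groups, so no measured step bears directly on the change. With two of three members at the limit and the third weak, the series gives no ground for expecting a large move in either direction. The expected step, then, is an at least 1.1-fold lower number from compound 1 to compound 4 (0.04 log units; that floor lies within the scatter), within the scatter or close to it, with a fair chance that compound 4 again returns only a limit. For compound 4 the estimate in this assay is 90000 nM, ranging from 30000 nM to 300000 nM.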

Compound 4, half-maximal inhibitory concentration: > 100000 nM
Compound 4: a limit, no number; the forecaster's own chance of this, stated with the estimate: 55%; at least 1.1-fold (0.04 log units) between middle value and limit.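

Compound 1 and compound 4 both return a limit and not a number in this assay, so the step between them, methylsulfonyl in place of trifluoromethyl, cannot be read: the limit of > 100000 nM in this assay, at which 3 of the 4 values shown sit.

The compounds shown leave open whether this exchange changes the read-out in this assay at all, in either direction.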